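Methoxy in Place of Trifluoromethyl on a Triazole-Linked Phenyl

A few compounds are considered here, and "the series" means these few. Any claim that something is new, unique, unknown or untested is made for them only; others in the source may bear on it.

Compound 1 `Cc1c(O)ccc2c1[C@H](Cn1cc(-c3ccccn3)nn1)[C@@]13CC(=O)[C@@](C)(CC[C@@H]21)C3`: in a functional assay on HL-60 cells (Homo sapiens) for cytotoxicity, read by MTT assay, with a stated time of 4 days (on this read-out lower numbers stand for stronger inhibition and higher numbers for weaker inhibition), compound 1 gives > 20000 nM, a limit of the assay and not a number.
Compound 2 `Cc1c(O)ccc2c1[C@H](Cn1cc(-c3ccc(C(F)(F)F)cc3)nn1)[C@@]13CC(=O)[C@@](C)(CC[C@@H]21)C3`: in this assay compound 2 gives > 20000 nM, again a limit of the assay.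

Compound 2 thus stands at the limit, and the step that the two limits leave unreadable from compound 1 to compound 2 cannot be read. Compound 3 `COc1ccc(-c2cn(C[C@H]3c4c(ccc(O)c4C)[C@@H]4CC[C@@]5(C)C[C@]43CC5=O)nn2)cc1` differs from compound 2 by methoxy in place of trifluoromethyl on an aromatic carbon. For the measured compounds named here, the one measured step concerns the same ring, yet it gives no direction or size because both of its values sit at the limit of > 20000 nM in this assay, at which 2 of the 2 values shown sit. No change beyond the scatter can be predicted, and a further limit is likely. Compound 3 is therefore expected near 30000 nM, within 10000 nM to 100000 nM. The expected step is a step that the limit leaves unreadable from compound 2 to compound 3.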

Compound 3, half-maximal inhibitory concentration: > 20000 nM
Compound 3 ended at the assay's limit (the forecaster's own chance of this, stated with the estimate: 80%); the middle value is on the limit's open side.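

Compound 1, compound 2 and compound 3 all sit at a limit of the assay and not at a number, so no step among them can be read: the limit of > 20000 nM in this assay, at which 3 of the 3 values shown sit.

From the compounds shown here alone, whether any group at this place on the shared core gives a measurable value in this assay stays open.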